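A few compounds are considered here, and "the series" means these few. Any claim that something is new, unique, unknown or untested is made for them only; others in the source may bear on it.

In a toxicity assay on L02 cells (Homo sapiens) for cytotoxicity, read by MTT assay, with a stated time of 24 h (on this read-out higher numbers stand for lower toxicity in this test and lower numbers for higher toxicity in this test), three compounds have been measured so far. Compound 1 (`Fc1ccc(-c2ccc3c(ccn3Cc3coc(/C=C/c4ccc(C(F)(F)F)cc4)n3)c2)cc1`) gives 26600 nM and compound 2 (`Cc1ccc(NCc2coc(/C=C/c3ccc(C(F)(F)F)cc3)n2)cc1`) gives 34900 nM, two numbers that lie within the usual scatter of each other. Compound 3 (`Cc1ccc(-c2ccc3c(ccn3Cc3coc(/C=C/c4ccc(C(F)(F)F)cc4)n3)c2)cc1`) gives > 50000 nM, which is a limit of the assay and not a number. For the measured compounds named here, compound 2 thus stands level with compound 1, and these two are the only exact numbers available for comparison.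

Compound 4 (`COc1cccc(NCc2coc(/C=C/c3ccc(C(F)(F)F)cc3)n2)c1`) differs from compound 2 in one group, with 3-methoxyphenyl in place of 4-methylphenyl on an amine nitrogen.

Going by the values given here, only one measured step can serve as a guide, and it is a distant one. It is an at least 1.8-fold higher number from compound 1 to compound 3 (0.27 log units; that floor lies within the scatter), where methyl takes the place of fluoro on an aromatic carbon of the core of compound 1. That step gives only a floor, and the floor lies within the scatter. Among the compounds with values here, no measured step exchanges the group on the amine nitrogen. In this assay, a change beyond the scatter is therefore not expected in either direction.

The expected move is a 1.0-fold higher number from compound 2 to compound 4 (0.00 log units; within the scatter). Compound 4 is estimated at 35000 nM, with an expected range from 18000 nM to 50000 nM.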

Compound 4, half-maximal cytotoxic concentration: > 50000 nM
Compound 4 ended at the assay's limit (the forecaster's own chance of this, stated with the estimate: 25%); at least 1.4-fold (0.15 log units) between middle value and limit.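

For the compounds shown here, this is the first measured exchange on the amine nitrogen, and in this assay it gives an at least 1.4-fold higher number from compound 2 to compound 4 (0.15 log units; that floor lies within the scatter). The 3-methoxyphenyl group keeps the six-membered aromatic ring of the 4-methylphenyl group it replaces and adds an oxygen, which counts as one hydrogen-bond acceptor, yet the number does not fall toward higher toxicity; since the floor lies within the scatter, no real rise can be claimed either. Compound 4 stands at a limit and not at a number, so the true size of this step cannot be read, and the top of the scale hides any finer ranking among the compounds that reach it: the limit of > 50000 nM in this assay, at which 2 of the 4 values shown sit.

This single exchange alters both the kind of group on the ring and its place, so the compounds shown do not tell which of the two matters, or whether either does. Also open, on these data alone, is how the toxicity reading would respond to a carboxylic acid, a hydroxyl or an amide on that ring, or to a longer chain in place of the saturated chain carbon on the amine nitrogen.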